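The source may report more compounds than this note shows. Statements on the series, on what has been measured and on what is new or still open speak of the compounds shown alone.

Measured so far in a functional assay on MGC-803 cells (Homo sapiens) for inhibition, read by MTT assay, with a stated time of 48 h; a higher number here means a weaker inhibitor, a lower number a stronger inhibitor:
compound 1, `CCC(=O)N(Cc1ccc(OC)c(O)c1)c1cc(OC)c(OC)c(OC)c1`, gives 50 nM
compound 2, `COc1ccc(CNc2cc(OC)c(OC)c(OC)c2)cc1Br`, gives 29400 nM

Compound 1 has the lower of these two numbers, and the gap to compound 2 lies beyond the usual scatter. Compound 3, `COc1ccc(CN(C(=O)CCCl)c2cc(OC)c(OC)c(OC)c2)cc1O`, differs from compound 1 by chloro in place of hydrogen on a saturated chain carbon, two bonds along the chain from a carbonyl carbon. Within the data shown here, no measured pair here shows what such a change does, so the expected step from compound 1 to compound 3 in this assay is small, with no clear direction beyond the scatter. Compound 3 is therefore estimated at 45 nM, between 15 nM and 150 nM, an expected step of a 1.1-fold lower number from compound 1 to compound 3 (0.05 log units; within the scatter).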

Compound 3, half-maximal inhibitory concentration: 140 nM
Compound 3: middle estimate off by 3.1-fold (0.49 log units), on the low side, within the range that was stated.
By their numbers in this assay, from the lowest: compound 1; then compound 3; then compound 2.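

In this assay, placing chloro in place of hydrogen on a saturated chain carbon, two bonds along the chain from a carbonyl carbon, gives a 2.8-fold higher number from compound 1 to compound 3 (0.45 log units; beyond the scatter), so compound 3 is a modestly weaker inhibitor. This position therefore responds to substitution, but this single atom weakens inhibition only modestly. No available evidence explains the step. As far as these compounds go, whether an amine, a hydroxyl or fluoro at the same carbon would behave like chloro remains open. So does the effect of a longer chain.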